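The source may report more compounds than this note shows. Statements on the series, on what has been measured and on what is new or still open speak of the compounds shown alone.

Three compounds have been measured in an ADME assay on L6 cells (Rattus norvegicus) for cytotoxicity; on this read-out higher numbers stand for weaker inhibition and lower numbers for stronger inhibition:

Compound 1 `O=C(Nc1c(O)cccc1-c1nc2c(C(=O)O)cccc2o1)c1ccccc1O` gives 85100 nM
Compound 2 `O=C(Nc1c(O)cccc1-c1nc2c(C(=O)O)cccc2o1)c1cccc(Cl)c1` gives 143000 nM
Compound 3 `O=C(Nc1c(O)cccc1-c1nc2c(C(=O)O)cccc2o1)c1cc2ccccc2[nH]1` gives 212000 nM

Compound 1 stands lowest of the three: a 1.7-fold higher number from compound 1 to compound 2 (0.23 log units; within the scatter), and a 2.5-fold higher number from compound 1 to compound 3 (0.40 log units; beyond the scatter). Between the other two, a 1.5-fold higher number from compound 2 to compound 3 (0.17 log units; within the scatter).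

Compound 4 `O=C(Nc1c(O)cccc1-c1nc2c(C(=O)O)cccc2o1)c1ncccc1O` differs from compound 1 in one place: 3-hydroxypyridin-2-yl in place of 2-hydroxyphenyl on a carbonyl carbon. All three measured steps exchange the group on the same carbonyl carbon, and each gives at most a modest rise in the number. None of them keeps the hydroxyl while exchanging a ring carbon for a nitrogen, so there is no direct guide for this particular change. The expected step is therefore small, a 1.2-fold higher number from compound 1 to compound 4 (0.07 log units; within the scatter), not beyond the scatter. Compound 4 is estimated at 100000 nM, within 50000 nM to 200000 nM.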

Compound 4, half-maximal inhibitory concentration: 14200 nM
Beside the measured number, compound 4's estimate is 7.0-fold (0.85 log units) above it; the whole stated range lies above it.
By their numbers in this assay, from the lowest: compound 4; then compounds 1, 2 and 3 (each within the scatter of the next, the first and the last beyond it).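

On this carbonyl carbon the number can fall as well as rise in this assay: 3-hydroxypyridin-2-yl in place of 2-hydroxyphenyl, a ring nitrogen for a ring carbon, gives a 6.0-fold lower number from compound 1 to compound 4 (0.78 log units; beyond the scatter). The other two comparisons show the same separation, with a 10-fold lower number from compound 2 to compound 4 (1.00 log units; beyond the scatter) and a 15-fold lower number from compound 3 to compound 4 (1.17 log units; beyond the scatter), so compound 4 lies beyond the scatter of all three earlier compounds, on the side of stronger inhibition. Nothing available explains this drop.

From the compounds shown here alone, it remains open whether the ring nitrogen alone accounts for the drop. A plain pyridin-2-yl, or an amine in place of the hydroxyl, would test how much the hydroxyl matters here.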